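Trimming the Phenethyl Ester of Compound 2 to Ethyl

This account rests on a few compounds, and the source may have more. Where it says the series, first, only, none or still open, it means among the compounds named here.

Three measured compounds share one core and differ only in the group on a double-bonded ring carbon. Compound 1 `COc1ccc2c(c1)OC(c1cc(OC)c(OC)c(OC)c1)C(C=O)=C2` gives 13500 nM in a functional assay for inhibition of nuclear factor NF-kappa-B complex (Homo sapiens); a higher number here means a weaker inhibitor, a lower number a stronger inhibitor. Compound 2 `COc1ccc2c(c1)OC(c1cc(OC)c(OC)c(OC)c1)C(C(=O)OCCc1ccccc1)=C2` gives 16200 nM, and compound 3 `CCOCC1=Cc2ccc(OC)cc2OC1c1cc(OC)c(OC)c(OC)c1` gives 21300 nM. Compound 2 holds the second highest of the three numbers, but that placement carries no weight, since a 1.2-fold higher number from compound 1 to compound 2 (0.08 log units; within the scatter) and a 1.3-fold higher number from compound 2 to compound 3 (0.12 log units; within the scatter) both sit within the scatter, as does a 1.6-fold higher number from compound 1 to compound 3 (0.20 log units; within the scatter). Compound 4 `CCOC(=O)C1=Cc2ccc(OC)cc2OC1c1cc(OC)c(OC)c(OC)c1` differs from compound 2 by hydrogen in place of phenyl on a saturated chain carbon, two bonds along the chain from an oxygen next to a carbonyl group, which cut one bond further out reads phenethyloxy to ethoxy. The step of a 1.3-fold higher number from compound 2 to compound 3 (0.12 log units; within the scatter) removed the whole phenethyloxycarbonyl without leaving the scatter, so the smaller trim in compound 4 is expected to give a step of a 1.0-fold lower number from compound 2 to compound 4 (0.01 log units; within the scatter) that stays within it. Compound 4 is therefore estimated at 16000 nM, ranging from 8000 nM to 32000 nM.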

Compound 4, half-maximal inhibitory concentration: 25000 nM
Estimate against measurement, compound 4: 1.6-fold (0.19 log units) below, within the range that was stated.
By their numbers in this assay, from the lowest: compounds 1, 2, 3 and 4 (each within the scatter of the next).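

Taking the phenyl off the ester chain gives a 1.5-fold higher number from compound 2 to compound 4 (0.19 log units; within the scatter) in this assay, so at this position a phenethyl ester and an ethyl ester cannot be told apart. The other new comparisons agree: ethoxycarbonyl against ethoxymethyl gives a 1.2-fold higher number from compound 3 to compound 4 (0.07 log units; within the scatter) and ethoxycarbonyl against formyl gives a 1.9-fold higher number from compound 1 to compound 4 (0.27 log units; within the scatter) on the same ring carbon, so all four groups remain within the scatter. No supporting evidence bears on these steps. Still open, on these data alone, is whether a carboxylic acid, an amide or an amine on this ring carbon would give a step beyond the scatter.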